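Swapping fluoro for methoxy in a low-inhibition series

A few compounds are considered here, and "the series" means these few. Any claim that something is new, unique, unknown or untested is made for them only; others in the source may bear on it.

Three related compounds have been measured so far in a functional assay on Bel-7402 cells (Homo sapiens) for inhibition, read by MTT assay, with a stated time of 24 h, tested at 10 ug/mL; on this read-out lower numbers stand for less inhibition of growth and higher numbers for more inhibition of growth at the one concentration tested. Compound 1 (`O=C(CCCCC1CCSS1)Nc1ccccc1Cl`) is reported as "not active" (no number reported), without a number. Compound 2 (`O=C(CCCCC(S)CCS)Nc1ccc(Cl)cc1`) gives 1.16%. Compound 3 (`O=C(CCCCC(S)CCS)Nc1ccc(F)cc1`) gives 6.14%, which lies within the usual scatter of the value for compound 2, and both numbers are small.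

The next compound, compound 4 (`COc1ccc(NC(=O)CCCCC(S)CCS)cc1`), keeps the core of compound 3 but carries methoxy in place of fluoro on an aromatic carbon. Among the compounds with values here, only one measured step bears on this change, a swap of fluoro in place of chloro on an aromatic carbon, and it gives a number 5 percentage points higher from compound 2 to compound 3 (within the scatter). Within the data shown here, that step stays within the scatter, and no measured compound carries methoxy, so the data point in neither direction. No step beyond the scatter is therefore expected, and the estimated step is a number 1.1 percentage points lower from compound 3 to compound 4 (within the scatter). The expected value for compound 4 is 5%, with an estimated range from 0% to 15%.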

Compound 4, percent growth inhibition at one concentration: 10.4%
Compound 4: middle estimate off by 5.4 percentage points, on the low side, and the stated range covers the measured number.
By their numbers in this assay, from the lowest: compounds 2, 3 and 4 (each within the scatter of the next).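

In this assay, the place on the aromatic ring para to a large group has now held chloro, fluoro and methoxy. Methoxy brings two heavy atoms and a hydrogen-bond acceptor where each halogen has one heavy atom and none, yet the step in place of fluoro is small (a number 4.3 percentage points higher from compound 3 to compound 4 (within the scatter)), and so is the step in place of chloro (a number 9.2 percentage points higher from compound 2 to compound 4 (within the scatter)). This larger change of group therefore still gives no difference that can be told from the scatter, and no measurement at hand bears on why the numbers fall as they do.

On these data alone, whether an amine or a carboxylic acid in this place would give a step beyond the scatter remains open. So does the effect of a longer chain on the oxygen of the methoxy group.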